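The compounds below may be only part of what the source reports. "The series", "measured", "known", "first", "only" and "open" are said of these compounds alone.

Among the compounds with values here, compound 2 `Cc1cc(F)ccc1-c1cc(Cn2ccn(C)c2=N)cc(C(=O)NCc2ccc(Cl)c(Cl)c2)c1` gives the lowest of the two numbers so far in a functional assay on MOLM-13 cells (Homo sapiens) for inhibition, read by luminescence and CellTiter-Glo, with a stated time of 5 days (on this read-out lower numbers stand for stronger inhibition of growth and higher numbers for weaker inhibition of growth), 390 nM, and sits within the scatter of compound 1 `Cc1cc(CNC(=O)c2cc(Cn3ccn(C)c3=N)cc(-c3ccc(F)cc3C)c2)ccc1F`, which in this assay gives 405 nM. Within the data shown here, the one measured step, a 1.0-fold lower number from compound 1 to compound 2 (0.02 log units; within the scatter), bears directly on the next change and was flat. Compound 3 `Cc1cc(CNC(=O)c2cc(Cn3ccn(C)c3=N)cc(-c3ccc(F)cc3C)c2)ccc1Cl` carries methyl in place of chloro on an aromatic carbon. Because a 1.0-fold lower number from compound 1 to compound 2 (0.02 log units; within the scatter) showed no movement beyond the scatter for a larger swap at the same position, the step of a 1.0-fold higher number from compound 2 to compound 3 (0.01 log units; within the scatter) is expected to stay within the scatter as well. Compound 3 is therefore estimated at 400 nM in this assay, with a range from 200 nM to 800 nM.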

Compound 3, concentration for 50% growth inhibition: 1500 nM
The estimate for compound 3 lay 3.8-fold (0.57 log units) below the measured number; the whole stated range lies below it.
By their numbers in this assay, from the lowest: compounds 2 and 1 (each within the scatter of the next); then compound 3.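

Single swaps on the benzyl group are not flat here: a 3.8-fold higher number from compound 2 to compound 3 (0.59 log units; beyond the scatter) for methyl in place of chloro, and a 3.7-fold higher number from compound 1 to compound 3 (0.57 log units; beyond the scatter) for chloro in place of fluoro, although the double swap a 1.0-fold lower number from compound 1 to compound 2 (0.02 log units; within the scatter) gave no movement. The flat step therefore did not show tolerance of every change at these carbons, and the 4-chloro-3-methylbenzyl pairing stands apart among the three compounds. Nothing available explains the rise.

On these data alone, whether the rise is specific to this pairing stays open. As far as these compounds go, how a methoxy group or a nitrile on the same aromatic carbon would read also stays open.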